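Chlorobenzyl Amide on a Nitrobenzamide Benzothiazole Core

The compounds below may be only part of what the source reports. "The series", "measured", "known", "first", "only" and "open" are said of these compounds alone.

Three compounds share one core. Compound 1 `O=C(CSc1nc2ccc(NC(=O)c3ccccc3)cc2s1)NCc1ccc(Cl)cc1` gives 30100 nM in a functional assay on HepG2 cells (Homo sapiens) for cytotoxicity, read by MTT assay, with a stated time of 48 h; a lower number here means a stronger inhibitor, a higher number a weaker inhibitor. Compound 2 `CNC(=O)CSc1nc2ccc(NC(=O)c3ccccc3)cc2s1` gives 26500 nM in this assay. The difference between them is 4-chlorophenyl in place of hydrogen on a saturated chain carbon bound to an amide-type nitrogen, and the step of a 1.1-fold higher number from compound 2 to compound 1 (0.06 log units; within the scatter) is small. Compound 3 `CNC(=O)CSc1nc2ccc(NC(=O)c3ccc([N+](=O)[O-])cc3)cc2s1` differs from compound 2 by nitro in place of hydrogen on an aromatic carbon, and the step of an at least 3.7-fold higher number from compound 2 to compound 3 (0.57 log units; beyond the scatter) is larger. In this assay compound 3 reaches only a limit of the assay, > 100000 nM. Compound 4 `O=C(CSc1nc2ccc(NC(=O)c3ccc([N+](=O)[O-])cc3)cc2s1)NCc1ccc(Cl)cc1` differs from compound 3 by 4-chlorophenyl in place of hydrogen on a saturated chain carbon bound to an amide-type nitrogen, the same change as that from compound 2 to compound 1. The step that the limit leaves unreadable from compound 3 to compound 4 is expected to be small because a 1.1-fold higher number from compound 2 to compound 1 (0.06 log units; within the scatter) was small. Compound 4 is therefore estimated at 150000 nM, with a range from 70000 nM to 400000 nM, and it is expected to sit at the limit of > 100000 nM in this assay, at which 1 of the 3 values shown sits.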

Compound 4, half-maximal inhibitory concentration: > 100000 nM
Compound 4: no number, only a limit (the forecaster's own chance of this, stated with the estimate: 75%); the middle value lies beyond the limit too.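

Nitro in place of hydrogen on an aromatic carbon gives an at least 3.3-fold higher number from compound 1 to compound 4 (0.52 log units; beyond the scatter) in this assay. The change therefore points the same way on both cores, and on each it lies beyond the scatter: the same change on two cores in this assay, an at least 3.7-fold higher number (0.57 log units; beyond the scatter) from compound 2 to compound 3 and an at least 3.3-fold higher number (0.52 log units; beyond the scatter) from compound 1 to compound 4; the limit leaves it open whether they differ. The value of compound 4, > 100000 nM, is a limit of the assay, which means that the steps fix only a minimum and do not show whether the change has the same size on both cores, and the step between compound 3 and compound 4 cannot be read.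

The compounds shown leave open how an amine or a carboxylic acid in place of the nitro would read in this assay. They also leave open what a longer chain in place of the methyl or the 4-chlorobenzyl would give.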